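The source may hold more compounds than are shown below. What is called first, only, known or untested is meant among the compounds shown, and "the series" means these compounds.

Measured in a functional assay on SGC-7901 cells (Homo sapiens) for inhibition, read by MTT assay, with a stated time of 72 h; a higher number here means a weaker inhibitor, a lower number a stronger inhibitor:
- compound 1 `CCC(=O)Nc1cccc(C(=O)/C=C2/C(=O)Nc3ccccc32)c1`: 11500 nM
- compound 2 `CC(C)C(=O)Nc1cccc(C(=O)/C=C2/C(=O)Nc3ccccc32)c1`: 8600 nM
- compound 3 `Nc1cccc(C(=O)/C=C2/C(=O)Nc3ccccc32)c1`: 14400 nM

Compound 3 (14400 nM) sits level with compound 1 and compound 2, since all three values lie within the scatter of one another. The next compound, compound 4 `C=CC(=O)Nc1cccc(C(=O)/C=C2/C(=O)Nc3ccccc32)c1`, has vinylcarbonyl in place of hydrogen on a nitrogen on an aromatic ring.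

The closest guides are compound 1 and compound 2, which carry propanoyl and isopropylcarbonyl on that same nitrogen. Removing these groups gave only small steps (a 1.3-fold higher number from compound 1 to compound 3 (0.10 log units; within the scatter) and a 1.7-fold higher number from compound 2 to compound 3 (0.22 log units; within the scatter)). Exchanging one group for the other was just as small (a 1.3-fold lower number from compound 1 to compound 2 (0.13 log units; within the scatter)). Among the compounds with values here, no compound measured so far carries vinylcarbonyl, so this new group remains an open question.

No step beyond the scatter is therefore expected in this assay, and the estimated change is a 1.6-fold lower number from compound 3 to compound 4 (0.20 log units; within the scatter). Compound 4 is expected at 9000 nM, with an estimated range of 3500 nM to 18000 nM.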

Compound 4, half-maximal inhibitory concentration: 5700 nM
Estimate against measurement, compound 4: 1.6-fold (0.20 log units) above; the measured number falls inside the stated range.
By their numbers in this assay, from the lowest: compounds 4, 2, 1 and 3 (each within the scatter of the next, the first and the last beyond it).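

In this assay, within the data shown here, vinylcarbonyl on the nitrogen of the aromatic ring gives the first step at this position that lies beyond the scatter, though only a modest one (a 2.5-fold lower number from compound 3 to compound 4 (0.40 log units; beyond the scatter)). Among these compounds, the earlier propanoyl and isopropylcarbonyl groups gave no such step from the free amino compound. Vinyl cannot be told apart from the other two groups on the carbonyl carbon, however, since both comparisons stay within the scatter (a 1.5-fold lower number from compound 2 to compound 4 (0.18 log units; within the scatter); a 2.0-fold lower number from compound 1 to compound 4 (0.30 log units; within the scatter)). Nothing shown here explains the step.

On these data alone, it remains open whether a longer chain or a phenyl ring on that carbonyl carbon would move the number further. A basic amine at the end of such a chain is equally untested among the compounds shown.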